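The compounds below may be only part of what the source reports. "The series", "measured", "known", "first", "only" and "open" are said of these compounds alone.

Compound 1 `COc1ccc(C(OCc2ccccc2)c2cccc3ccccc23)c(OC)c1OC` sits at the limit of a functional assay on HCT-116 cells (Homo sapiens) for inhibition, read by sulforhodamine B assay, with a stated time of 48 h; on this read-out lower numbers stand for stronger inhibition and higher numbers for weaker inhibition: in this assay compound 1 gives > 20000 nM, which is a limit rather than a number. Compound 2 `COc1ccc(C(O)(Cc2ccc(C)cc2)c2cccc3ccccc23)c(OC)c1OC` likewise gives only a limit, > 20000 nM. Compound 3 `COc1ccc(C(O)(Cc2ccccc2)c2cccc3ccccc23)c(OC)c1OC` also gives a limit, > 20000 nM. The step that the two limits leave unreadable from compound 2 to compound 3 therefore cannot be read, and across the three compounds the limit of > 20000 nM in this assay, at which 3 of the 3 values shown sit, is all that the measurements show. Compound 4 `C=CCOC(c1ccc(OC)c(OC)c1OC)c1cccc2ccccc12` differs from compound 1 by vinyl in place of phenyl on a saturated chain carbon bound to an oxygen on a saturated carbon. Going by the values given here, no measured step bears on this change, since every value shown sits at the limit. Compound 4 is therefore expected to remain near that limit, with a step that the limit leaves unreadable from compound 1 to compound 4 expected to be no step beyond the scatter. Compound 4 is estimated at 30000 nM in this assay, within 12000 nM to 100000 nM.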

Compound 4, half-maximal inhibitory concentration: > 20000 nM
Compound 4: no number, only a limit (the forecaster's own chance of this, stated with the estimate: 85%); the middle value lies beyond the limit too.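

Going by these compounds alone, compound 4, like compound 1, gives only a limit in this assay, so no step between compound 1 and compound 4 can be read. The compounds shown leave open whether any change to the shared core would bring a value inside the range that can be read: the limit of > 20000 nM in this assay, at which 4 of the 4 values shown sit.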